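Triazole series: chloro-to-methyl swap on the aryl ring

The source may report more compounds than this note shows. Statements on the series, on what has been measured and on what is new or still open speak of the compounds shown alone.

Compound 1 `Cc1cc(Cl)ccc1-c1n[nH]c(-c2ccccc2)n1` and compound 2 `Cc1ccc(-c2n[nH]c(-c3ccccc3)n2)c(C)c1` share one core; compound 3 `COc1cccc(-c2n[nH]c(-c3ccc(Cl)cc3C)n2)c1` carries a different core, and the difference between the two cores is not broken down here. In a functional assay on the whole organism (Cricetulus griseus) with Cricetinae gen. sp. as the target (on this read-out higher numbers stand for an effect only at larger amounts of compound and lower numbers for an effect already at smaller amounts), compound 1 gives 0.14 mg/kg, compound 2 gives 0.2 mg/kg and compound 3 gives 0.04 mg/kg. The number of compound 3 is the lowest of the three measured, and its gaps to compound 1 and to compound 2 both lie beyond the scatter. The change methyl in place of chloro on an aromatic carbon gives a 1.4-fold higher number from compound 1 to compound 2 (0.15 log units; within the scatter). Compound 4 `COc1cccc(-c2n[nH]c(-c3ccc(C)cc3C)n2)c1`, not yet measured, is the same change applied to compound 3: methyl in place of chloro on an aromatic carbon. The surroundings of the exchanged group read the same in both cases, so it is treated as the same change. Going by the values given here, for compound 4 the expected step is a 1.4-fold higher number from compound 3 to compound 4 (0.14 log units; within the scatter), resting on the only earlier instance of this change, a 1.4-fold higher number from compound 1 to compound 2 (0.15 log units; within the scatter). Compound 4 is therefore estimated at 0.055 mg/kg in this assay, with a range from 0.025 mg/kg to 0.12 mg/kg.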

Compound 4, dose for half-maximal effect: 0.04 mg/kg
Compound 4: middle estimate off by 1.4-fold (0.14 log units), on the high side; measured number inside the range.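

In this assay, methyl in place of chloro on an aromatic carbon gives no change at the digits printed from compound 3 to compound 4 (within the scatter), and the step does not differ from the earlier instance of the change: the same change on two cores in this assay, a 1.4-fold higher number (0.15 log units; within the scatter) from compound 1 to compound 2 and no change at the digits printed (within the scatter) from compound 3 to compound 4, 1.4-fold (0.15 log units) apart, within the scatter of two such steps

On these two cores, then, the exchange of chloro for methyl stays within the scatter, and its step carries over from the core of compound 1 to the core of compound 3. This does not show that the change would carry to any further core, and a step within the scatter cannot separate a small real effect from none, so two steps support only a statement about these two pairs.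

From the compounds shown here alone, what a nitrile, an amine or a carboxylic acid at this place would do to the number in this assay remains open. Going by these compounds alone, also open is what the difference between the two cores contributes by itself, as no single-place step connects them.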